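The source may hold more compounds than are shown below. What is called first, only, known or untested is meant among the compounds shown, and "the series" means these compounds.

Measured so far, all in a functional assay on A549 cells (Homo sapiens) for inhibition, read by CCK-8 assay, with a stated time of 72 h, tested at 1 uM; on this read-out lower numbers stand for a weaker effect and higher numbers for a stronger effect at the one concentration tested:

Compound 1 `CN(C)C(=O)c1cc2cnc(Nc3ccc(C(=O)NCCCCN=C=S)cc3F)nc2n1C1CCCC1` gives -7%.
Compound 2 `CN(C)C(=O)c1cc2cnc(Nc3ccc(C(=O)NCCCCCN=C=S)cc3F)nc2n1C1CCCC1` gives -1.6%.
Compound 3 `CN(C)C(=O)c1cc2cnc(Nc3ccc(C(=O)NCCCCCCN=C=S)cc3F)nc2n1C1CCCC1` gives -11.8%.

All three numbers sit near zero. Compound 3 is separated beyond the scatter only from compound 2 a number 10.2 percentage points lower from compound 2 to compound 3 (beyond the scatter); against compound 1 the gap a number 4.8 percentage points lower from compound 1 to compound 3 (within the scatter) stays within the scatter, so no ordering of compound 3 against compound 1 can be drawn.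

The next member, compound 4 `CN(C)C(=O)c1cc2cnc(Nc3ccc(C(=O)NCCCCCCCN=C=S)cc3F)nc2n1C1CCCC1`, is not yet measured. It differs from compound 3 by a group of 4 heavy atoms (2 carbon, 1 nitrogen, 1 sulfur; no ring) in place of a group of 3 heavy atoms (1 carbon, 1 nitrogen, 1 sulfur; no ring), on a saturated chain carbon, six bonds along the chain from an amide-type nitrogen.

The three measured steps all concern the same kind of change, a longer chain between the amide-type nitrogen and the isothiocyanate end. Two of them, a number 5.4 percentage points higher from compound 1 to compound 2 (within the scatter) and a number 4.8 percentage points lower from compound 1 to compound 3 (within the scatter), lie within the scatter; only a number 10.2 percentage points lower from compound 2 to compound 3 (beyond the scatter) is beyond it, and modest. Nothing in these steps suggests that one more chain carbon should move the read-out far in either direction; the expectation is a step of no size beyond the scatter.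

Compound 4 is therefore expected to give about -8%, in a range from -22% to 6%, an estimated step of a number 3.8 percentage points higher from compound 3 to compound 4 (within the scatter).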

Compound 4, a percentage reported as inhibition, at one concentration (the size of the read-out at that concentration, not a potency): 0.05%
Compound 4: the middle estimate sits 8.1 percentage points below what was measured; measured number inside the range.
By their numbers in this assay, from the lowest: compounds 3, 1, 2 and 4 (each within the scatter of the next, the first and the last beyond it).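

In this assay, the change six bonds along the chain from an amide-type nitrogen gives a number 11.9 percentage points higher from compound 3 to compound 4 (beyond the scatter), so the low number of compound 3 does not extend into a downward run with chain length, and compound 4 sits within the scatter of both shorter chains: a number 1.7 percentage points higher from compound 2 to compound 4 (within the scatter) and a number 7.1 percentage points higher from compound 1 to compound 4 (within the scatter). Chain length therefore shows no steady trend across these four compounds: compound 3 stands apart from compound 2 and compound 4 but not from compound 1, and it is the one compound that breaks any reading of the series as flat. The same change read at two chain lengths gives steps that cannot be told apart: the same change on two cores in this assay, a number 5.4 percentage points higher (within the scatter) from compound 1 to compound 2 and a number 11.9 percentage points higher (beyond the scatter) from compound 3 to compound 4, 6.5 percentage points apart, within the scatter of two such steps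

On these data alone, with compound 4 at 0.05%, the series still holds no number clearly showing inhibition, so it remains open whether any chain end on the shared core gives a real effect at this single concentration. An amine or a carboxylic acid in place of the isothiocyanate, or a longer chain, would test whether this position can move the read-out at all.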